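From Ethoxy to Phenyl on a Carbonyl Carbon

The source may report more compounds than this note shows. Statements on the series, on what has been measured and on what is new or still open speak of the compounds shown alone.

Measured so far in a functional assay on Raji cells (Homo sapiens) for cytotoxicity, with a stated time of 72 h; on this read-out higher numbers stand for an effect only at larger amounts of compound and lower numbers for an effect already at smaller amounts:
- Compound 1 `C=C[C@@](C)(/C=C/c1ccc(O)cc1)CCC1OC1(C)C`: > 22500 nM
- Compound 2 `C=C[C@@](C)(/C=C/c1ccc(O)cc1)CCC(O)C(C)(C)O`: > 26000 nM
- Compound 3 `C=C[C@@](C)(/C=C/c1ccc(O)cc1)CC/C=C/C(=O)OCC`: > 26000 nM

Each of these entries is a limit of the assay and not a number. Compound 3 stands at the limit of > 26000 nM in this assay, at which 2 of the 3 values shown sit, and compound 2 shares that limit. Compound 1 stands at the limit of > 22500 nM in this assay, at which 1 of the 3 values shown sits. Within the data shown here, no compound in this small set has yet given a true number, so none can be ranked against another.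

Compound 4 `C=C[C@@](C)(/C=C/c1ccc(O)cc1)CC/C=C/C(=O)c1ccccc1` differs from compound 3 by one change, with phenyl in place of ethoxy on a carbonyl carbon.

The nearest evidence is the set of measured changes at the same chain position, which are a step that the two limits leave unreadable from compound 1 to compound 3 and a step that the two limits leave unreadable from compound 2 to compound 3. The remaining comparison is a step that the two limits leave unreadable from compound 1 to compound 2. None of these gives a usable size, so they offer no measured basis for a direction. Three different end groups on this chain have nonetheless all ended at a limit, and the most likely outcome is that compound 4 does the same.

The expected change in this assay is an at least 1.1-fold lower number from compound 3 to compound 4 (0.07 log units; that floor lies within the scatter), and this remains a cautious estimate. For compound 4 the estimated value is 22000 nM, with an expected range from 9000 nM to 40000 nM.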

Compound 4, half-maximal effective concentration: > 26000 nM
Compound 4 was reported as a limit; the forecaster's own chance of this, stated with the estimate: 60%; middle value at least 1.1-fold (0.07 log units) from the limit.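

In this assay compound 3 and compound 4 are both reported as limits and not as numbers, so no step can be read between them, and they sit at the same limit: the limit of > 26000 nM in this assay, at which 3 of the 4 values shown sit.

The compounds shown leave open whether any end group on this chain can give a true number in this assay, and what size of step phenyl in place of ethoxy really makes.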